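The source may report more compounds than this note shows. Statements on the series, on what has been measured and on what is new or still open speak of the compounds shown alone.

Measured so far:
Compound 1 `COc1cc(-c2nn(-c3cccc(NC(=O)c4cccc(C(F)(F)F)c4)c3)cc2-c2ccncc2)ccc1Cl` — in a functional assay on SF-539 cells (Homo sapiens) for inhibition, read by sulforhodamine B assay, with a stated time of 48 h (a higher number here means a weaker inhibitor of growth, a lower number a stronger inhibitor of growth), compound 1 gives 2300 nM.
Compound 2 `COc1cc(-c2nn(-c3cccc(NC(=O)Nc4ccc(Cl)c(C(F)(F)F)c4)c3)cc2-c2ccncc2)ccc1Cl` — in this assay compound 2 gives 6340 nM.

Among the compounds with values here, compound 2 stands with the higher of the two numbers; its only neighbour is compound 1, and the single measured step is a 2.8-fold higher number from compound 1 to compound 2 (0.44 log units; beyond the scatter). Compound 3 `COc1cc(-c2nn(-c3cccc(NC(=O)c4ccccc4)c3)cc2-c2ccncc2)ccc1Cl` is not yet measured. From compound 2 it carries phenyl in place of (4-chloro-3-(trifluoromethyl)phenyl)amino on a carbonyl carbon. Within the data shown here, this change undoes the one measured step but also removes the trifluoromethyl present in compound 1, a part with no measured comparison. A step of a 2.5-fold lower number from compound 2 to compound 3 (0.40 log units; beyond the scatter) is expected, back toward the number of compound 1. Compound 3 is therefore estimated at 2500 nM, within 900 nM to 7000 nM.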

Compound 3, concentration for total growth inhibition: 2880 nM
Compound 3: the middle estimate sits 1.2-fold (0.06 log units) below what was measured, within the range that was stated.
By their numbers in this assay, from the lowest: compounds 1 and 3 (each within the scatter of the next); then compound 2.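

In this assay, hydrogen in place of trifluoromethyl on an aromatic carbon gives a 1.3-fold higher number from compound 1 to compound 3 (0.10 log units; within the scatter), so this group can go from the phenyl on the carbonyl carbon without a readable change. Phenyl in place of (4-chloro-3-(trifluoromethyl)phenyl)amino gives a 2.2-fold lower number from compound 2 to compound 3 (0.34 log units; beyond the scatter), so the higher number of compound 2 goes with that larger group as a whole, not with trifluoromethyl alone. Nothing available gives a reason for either step.

Which part of (4-chloro-3-(trifluoromethyl)phenyl)amino carries the step stays open. So does the effect of an amine or a carboxylic acid on that phenyl.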